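Aryl to sulfonamide exchange on the five-membered ring

This account rests on a few compounds, and the source may have more. Where it says the series, first, only, none or still open, it means among the compounds named here.

Compound 1 `O=C1O[C@H]([C@@H](O)Cn2cc(-c3cccc(O)c3)nn2)C(OCc2ccccc2)=C1OCc1ccccc1` carries 3-hydroxyphenyl on the five-membered aromatic ring; in a functional assay on HCT-116 cells (Homo sapiens) for antiproliferative activity, read by MTT assay, with a stated time of 72 h (on this read-out higher numbers stand for weaker inhibition and lower numbers for stronger inhibition), compound 1 gives 42900 nM. Compound 2 `Cc1ccc(-c2cn(C[C@H](O)[C@H]3OC(=O)C(OCc4ccccc4)=C3OCc3ccccc3)nn2)cc1` bears 4-methylphenyl at that position. In this assay compound 2 reaches only > 100000 nM, which is a limit of the assay and not a number. Going by the values given here, the sole measured step is an at least 2.3-fold higher number from compound 1 to compound 2 (0.36 log units; beyond the scatter), ending at the limit of > 100000 nM in this assay, at which 1 of the 2 values shown sits, so compound 2 stands at the weak end of what the assay reports. Compound 3 `Cc1ccc(S(=O)(=O)NCc2cn(C[C@H](O)[C@H]3OC(=O)C(OCc4ccccc4)=C3OCc3ccccc3)nn2)cc1` differs from compound 2 by (((4-methylphenyl)sulfonyl)amino)methyl in place of 4-methylphenyl on an aromatic carbon. No measured step covers this exchange; its size in this assay cannot be anticipated from the pair shown, and a result at the limit remains possible. Compound 3 is estimated at 70000 nM, between 20000 nM and 200000 nM, an expected step of an at least 1.4-fold lower number from compound 2 to compound 3 (0.15 log units; that floor lies within the scatter).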

Compound 3, half-maximal inhibitory concentration: 13100 nM
Compound 3: the middle estimate sits 5.3-fold (0.73 log units) above what was measured, and the stated range ends above it.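

In this assay this position accepts the larger (((4-methylphenyl)sulfonyl)amino)methyl group with stronger inhibition: the exchange gives an at least 7.6-fold lower number from compound 2 to compound 3 (0.88 log units; beyond the scatter), and the same group set against 3-hydroxyphenyl gives a 3.3-fold lower number from compound 1 to compound 3 (0.52 log units; beyond the scatter). Compound 2 stands at a limit of the assay and not a number, so the first step is only a floor: the limit of > 100000 nM in this assay, at which 1 of the 3 values shown sits. Compound 2 and compound 3 both hold 4-methylphenyl, so that ring alone does not set the read-out here.

The compounds shown leave open whether an amide in place of the sulfonyl, or a longer chain, would keep this stronger inhibition.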